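A few compounds are considered here, and "the series" means these few. Any claim that something is new, unique, unknown or untested is made for them only; others in the source may bear on it.

Three compounds share a measurement in a functional assay on the whole organism (artery, strain albino) with Rattus norvegicus as the target, with a stated time of 120 min, at a dose of 10 mg/kg by the oral route; a lower number here means less inhibition, a higher number more inhibition at the dose given (going by the name of the read-out). Compound 1 `COc1ccc(C2N=C(SCc3ccccc3)NC(C)=C2C(=O)Nc2ccc(F)cc2)cc1OC` gives 8.8% in this assay. Compound 2 `COc1ccc(C2N=C(SCc3cccc(Cl)c3)NC(C)=C2C(=O)Nc2ccc(F)cc2)cc1OC` differs from compound 1 in one place, (chloro in place of hydrogen on an aromatic carbon), and in this assay compound 2 gives 10.8%. The step of a number 2 percentage points higher from compound 1 to compound 2 (within the scatter) is small. Compound 3 `CC1=C(C(=O)Nc2ccc([N+](=O)[O-])cc2)C(c2ccc(Br)cc2)N=C(SCc2ccccc2)N1` is built on another core; the difference between the two cores is not broken down here. In this assay compound 3 gives 13.4%. All three numbers lie within the scatter of one another, so no order among them can be read.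

Among the compounds with values here, compound 4 `CC1=C(C(=O)Nc2ccc([N+](=O)[O-])cc2)C(c2ccc(Br)cc2)N=C(SCc2ccccc2Cl)N1` has no measurement yet. It differs from compound 3 by chloro in place of hydrogen on an aromatic carbon. Within the data shown here, this is the same kind of change as the one from compound 1 to compound 2, but not the same: there the chloro enters meta to a large group, here it enters ortho to a large group. Because the earlier step of a number 2 percentage points higher from compound 1 to compound 2 (within the scatter) stayed within the scatter, a step of about a number 1.6 percentage points higher from compound 3 to compound 4 (within the scatter) is expected in this assay. On that basis compound 4 is estimated to give 15% in this assay, with a likely range from 5% to 27%.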

Compound 4, a percentage reported as inhibition, in the whole organism at one dose (the size of the read-out at that dose, not a potency): 7.7%
Beside the measured number, compound 4's estimate is 7.3 percentage points above it; the range from low to high includes it.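

In this assay, the new step is a number 5.7 percentage points lower from compound 3 to compound 4 (within the scatter), so adding the chloro shows no readable effect on this core. Set beside the earlier step, the same change cannot be told apart on the two cores: the same change on two cores in this assay, a number 2 percentage points higher (within the scatter) from compound 1 to compound 2 and a number 5.7 percentage points lower (within the scatter) from compound 3 to compound 4, 7.7 percentage points apart, within the scatter of two such steps. This does not show that the change carries over with a set size or direction: neither step can be told from no change at all, and the chloro stands ortho to a large group in compound 4 but elsewhere in compound 2.

Going by these compounds, all four compounds keep a benzylsulfanyl group or a chlorinated form of it, so it stays open whether replacing that group with a longer chain or an amine would move the read-out beyond the scatter. On these data alone, it also stays open whether a chloro placed in the same position on both cores would give two steps that match, and whether any of this would hold at another dose.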